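Sulfonyl substituent change in a urea-linked series

The source may report more compounds than this note shows. Statements on the series, on what has been measured and on what is new or still open speak of the compounds shown alone.

Measured so far:
- compound 1 `O=C(NCc1ccc(S(=O)(=O)c2cccc(C(F)(F)F)c2)cc1)N1Cc2ccncc2C1`; in a functional assay on A2780 cells (Homo sapiens) for cytotoxicity, read by sulforhodamine B assay, with a stated time of 72 h (on this read-out higher numbers stand for weaker inhibition and lower numbers for stronger inhibition), compound 1 gives 2.7 nM
- compound 2 `CC(C)n1cc(S(=O)(=O)c2ccc(CNC(=O)N3Cc4ccncc4C3)cc2)cn1`; in this assay compound 2 gives 11 nM
- compound 3 `O=C(NCc1ccc(S(=O)(=O)C2CCCOC2)cc1)N1Cc2ccncc2C1`; in this assay compound 3 gives 32 nM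

All three share the same core and differ only in the group on the sulfonyl sulfur. Compound 2 stands second highest of the three numbers: its nearest neighbour is compound 3, with a 2.9-fold higher number from compound 2 to compound 3 (0.46 log units; beyond the scatter), and the furthest is compound 1, with a 4.1-fold higher number from compound 1 to compound 2 (0.61 log units; beyond the scatter). The full span of the set is a 12-fold higher number from compound 1 to compound 3 (1.07 log units; beyond the scatter).

Compound 4 `O=C(NCc1ccc(S(=O)(=O)N2CC3(CCOCC3)C2)cc1)N1Cc2ccncc2C1` is not yet measured. Relative to compound 2 the change is a group of 9 heavy atoms (7 carbon, 1 nitrogen, 1 oxygen; one four-membered non-aromatic ring with 1 hetero atom, one six-membered non-aromatic ring with 1 hetero atom) in place of a group of 8 heavy atoms (6 carbon, 2 nitrogen; one five-membered aromatic ring with 2 hetero atoms), on a sulfonyl sulfur.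

The step that bears most directly on this is a 2.9-fold higher number from compound 2 to compound 3 (0.46 log units; beyond the scatter), where an aromatic group on the sulfonyl sulfur was exchanged for a saturated oxygen-containing ring. Within the data shown here, the entering group in compound 4 is likewise saturated, so a step in the same direction, of modest size, is expected; the data hold no example of a nitrogen bound to the sulfonyl sulfur, so the width of the range is kept generous. For compound 4 in this assay the expected value is 40 nM, with a range of 12 nM to 130 nM, which means an estimated step of a 3.6-fold higher number from compound 2 to compound 4 (0.56 log units; beyond the scatter).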

Compound 4, half-maximal inhibitory concentration: 10 nM
For compound 4 the middle estimate is 4.0-fold (0.60 log units) above the measured one; the measured number lies below the stated range.
By their numbers in this assay, from the lowest: compound 1; then compounds 4 and 2 (each within the scatter of the next); then compound 3.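

In this assay, the group with four-membered and six-membered non-aromatic rings, joined through its nitrogen to the sulfonyl sulfur, gives a 1.1-fold lower number from compound 2 to compound 4 (0.04 log units; within the scatter), so this non-aromatic group and the aromatic 1-isopropyl-1H-pyrazol-4-yl cannot be told apart at this position. The non-aromatic groups on the sulfonyl sulfur also do not behave as one class, as shown by a 3.2-fold lower number from compound 3 to compound 4 (0.51 log units; beyond the scatter). The 3-(trifluoromethyl)phenyl group still holds the lowest number of the set, with a 3.7-fold higher number from compound 1 to compound 4 (0.57 log units; beyond the scatter), which shows that the new group does not close the gap to compound 1.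

No measurement is at hand that explains any of these differences. From the compounds shown here alone, it remains open whether the number depends on the nitrogen attachment or on the rest of the entering group, which a morpholine or a piperidine on the sulfonyl sulfur would help to separate, and whether the trifluoromethyl group matters for compound 1, which an unsubstituted phenyl would test.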